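A few compounds are considered here, and "the series" means these few. Any claim that something is new, unique, unknown or untested is made for them only; others in the source may bear on it.

Compound 1 `C#CCSc1nc(Nc2ccccc2)c2ccncc2n1` is the starting point. In a functional assay on PC-3 cells (Homo sapiens) for inhibition, read by MTT assay, with a stated time of 72 h (on this read-out higher numbers stand for weaker inhibition and lower numbers for stronger inhibition), compound 1 gives > 80000 nM, which is a limit of the assay rather than a measured number. Compound 2 `C#CCSc1nc(Nc2ccc(C)cc2)c2ccncc2n1` carries a methyl in place of hydrogen on an aromatic carbon, and in this assay compound 2 gives 15700 nM. Among the measured compounds shown here, that single step, an at least 5.0-fold lower number from compound 1 to compound 2 (0.70 log units; beyond the scatter), is the only measured comparison available, and its true size is capped by the limit of > 80000 nM in this assay, at which 1 of the 2 values shown sits. The change to compound 3 `C#CCSc1nc(Nc2ccccc2Cl)c2ccncc2n1` is chloro in place of hydrogen on an aromatic carbon. For the measured compounds named here, the methyl step bears on this as the one example of adding a group to the same phenyl ring, but the chloro enters at a different carbon, so only a modest move from the starting point is expected. Compound 3 is expected at 45000 nM, between 12000 nM and 120000 nM, a step of an at least 1.7-fold lower number from compound 1 to compound 3 (0.24 log units; that floor lies within the scatter) in this assay, with a fair chance that the assay once more returns only a limit.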

Compound 3, half-maximal inhibitory concentration: > 80000 nM
Compound 3 gave a limit, no number; the forecaster's own chance of this, stated with the estimate: 40%; at least 1.7-fold (0.24 log units) between middle value and limit.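

In this assay compound 3 gives > 80000 nM, which is a limit of the assay and not a number. The step from hydrogen to chloro cannot be read, because compound 1 also ends at a limit, so neither end of that step has a measured number: the limit of > 80000 nM in this assay, at which 2 of the 3 values shown sit. What is new is that adding a group to the phenyl ring does not by itself bring a measurable value: the 2-chlorophenyl group, with its chloro ortho to a large group, gives an at least 5.0-fold higher number from compound 2 to compound 3 (0.70 log units; beyond the scatter).

That step swaps both the group and the ring carbon that carries it, so the compounds shown cannot say which of the two matters. They also leave open how an amine or a methoxy group on the same phenyl ring would read in this assay.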